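Chalcone acetamides: replacing the chloro of compound 2

The compounds below may be only part of what the source reports. "The series", "measured", "known", "first", "only" and "open" are said of these compounds alone.

Of the compounds shown here, three have been measured in a functional assay on SMMC-7721 cells (Homo sapiens) for cytotoxicity, read by MTT assay, with a stated time of 72 h; a higher number here means a weaker inhibitor, a lower number a stronger inhibitor. Compound 1 `O=C(CCl)Nc1ccc(C(=O)/C=C/c2ccccc2)cc1` gives 12600 nM in this assay. Compound 2 `O=C(CCl)Nc1ccc(C(=O)/C=C/c2ccccc2Cl)cc1` gives 11100 nM, and compound 3 `Cc1ccc(/C=C/C(=O)c2ccc(NC(=O)CCl)cc2)cc1` gives 22900 nM. In this assay compound 2 holds the lowest of the three numbers; the step of a 1.1-fold lower number from compound 1 to compound 2 (0.06 log units; within the scatter) is within the scatter, while the step of a 2.1-fold higher number from compound 2 to compound 3 (0.31 log units; beyond the scatter) is modest but beyond it.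

Compound 4 `O=C(CSC(=S)N[C@H]1CCOC1=O)Nc1ccc(C(=O)/C=C/c2ccccc2Cl)cc1` is not yet measured. Relative to compound 2 the change is a group of 10 heavy atoms (5 carbon, 1 nitrogen, 2 oxygen, 2 sulfur; one five-membered non-aromatic ring with 1 hetero atom) in place of one chlorine atom, on a saturated chain carbon bound to a carbonyl carbon. This position has not been touched by any of the measured steps: a 1.1-fold lower number from compound 1 to compound 2 (0.06 log units; within the scatter) and a 1.8-fold higher number from compound 1 to compound 3 (0.26 log units; within the scatter) both concern the aromatic ring at the far end of the shared core, and a 2.1-fold higher number from compound 2 to compound 3 (0.31 log units; beyond the scatter) exchanges that whole ring. Nothing measured therefore bears directly on the chain carbon bound to the carbonyl carbon, and the size of the change, by count of atoms, is far larger than any step recorded so far.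

Among the measured compounds shown here, with no comparable step available, only a loose expectation is possible: compound 4 is expected to give about 6000 nM in this assay, within 1500 nM to 25000 nM, which would mean an estimated step of a 1.9-fold lower number from compound 2 to compound 4 (0.27 log units; within the scatter).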

Compound 4, half-maximal inhibitory concentration: 20400 nM
The estimate for compound 4 lay 3.4-fold (0.53 log units) below the measured number; the range from low to high includes it.
By their numbers in this assay, from the lowest: compounds 2, 1, 4 and 3 (each within the scatter of the next, the first and the last beyond it).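

In this assay, among the compounds shown here, the step of a 1.8-fold higher number from compound 2 to compound 4 (0.26 log units; within the scatter) gives the first reading at the saturated chain carbon bound to a carbonyl carbon, and it stays within the scatter even though a group of 10 heavy atoms, with one five-membered non-aromatic ring with 1 hetero atom, replaces one chlorine atom. For this one pair, then, the chlorine atom is not required for a number of this size, and a much larger group at this place gives a reading that cannot be told apart from that of compound 2. The data shown offer no measurement that could account for this result.

Going by these compounds, with a single entering group, it stays open which of its parts matter, and whether the result would hold for simpler groups on the same carbon, such as a plain amine, a carboxylic acid or a short alkyl chain. On these data alone, it also stays open whether the small differences seen at the far aromatic ring of the shared core would carry over when this larger group is present.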